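The compounds below may be only part of what the source reports. "The series", "measured", "known", "first", "only" and "open" are said of these compounds alone.

Three isomers on one shared core have been measured so far. Compound 1 `Oc1ccc(-c2cc(-c3ccc(O)cc3)nc(-c3ccccc3O)c2)cc1` carries 4-hydroxyphenyl and 2-hydroxyphenyl groups; compound 2 `Oc1ccc(-c2cc(-c3ccccc3O)nc(-c3ccccc3O)c2)cc1` and compound 3 `Oc1ccc(-c2cc(-c3cccc(O)c3)cc(-c3ccccc3O)n2)cc1` each exchange one 4-hydroxyphenyl for a 2-hydroxyphenyl or a 3-hydroxyphenyl. All three were run in a functional assay on HCT-15 cells (Homo sapiens) for cytotoxicity, read by CCK-8 assay, with a stated time of 4 days; a lower number here means a stronger inhibitor, a higher number a weaker inhibitor. In this assay compound 1 gives > 50000 nM, which is a limit of the assay and not a number. In this assay compound 2 gives > 50000 nM, again a limit. In this assay compound 3 gives > 50000 nM, also a limit. Compound 2 thus stands where every value of the series stands, at the limit of > 50000 nM in this assay, at which 3 of the 3 values shown sit. The two measured steps, a step that the two limits leave unreadable from compound 1 to compound 2 and a step that the two limits leave unreadable from compound 1 to compound 3, cannot be sized since both ends sit at the limit of > 50000 nM in this assay, at which 3 of the 3 values shown sit.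

Compound 4 `Oc1ccccc1-c1cc(-c2ccccc2O)nc(-c2ccccc2O)c1` is the remaining isomer. Against compound 2 the change is 2-hydroxyphenyl in place of 4-hydroxyphenyl on an aromatic carbon. The two measured steps are the only ones that bear on it, and both also replace a 4-hydroxyphenyl with a ring bearing the hydroxyl elsewhere; neither gives a readable size or direction. Going by the values given here, no step beyond the scatter can be expected from them, and no step at all can be read. Compound 4 is therefore expected to give about 70000 nM in this assay, within 30000 nM to 200000 nM, most probably reported again as a limit. The step this estimate implies is a step that the limit leaves unreadable from compound 2 to compound 4.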

Compound 4, half-maximal inhibitory concentration: 2180 nM
Estimate against measurement, compound 4: 32-fold (1.51 log units) above; the whole stated range lies above it.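

In this assay, going by these compounds alone, the exchange of 4-hydroxyphenyl for 2-hydroxyphenyl on the aromatic carbon opposite the ring nitrogen gives the first readable step, an at least 22-fold lower number from compound 2 to compound 4 (1.36 log units; beyond the scatter). Within the data shown here, the earlier steps, which moved the hydroxyl on a ring at another place on the shared core, cannot be read, so this is the first sign that the hydroxyl's site on an aryl group matters, and it shows up at the place opposite the ring nitrogen, with two 2-hydroxyphenyl groups meta to it. Compound 4, which carries only 2-hydroxyphenyl groups, is the one compound of the four that stands off the limit: the limit of > 50000 nM in this assay, at which 3 of the 4 values shown sit.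

Still open is whether the gain belongs to the 2-hydroxyphenyl opposite the ring nitrogen alone or depends on the two 2-hydroxyphenyl groups meta to it, since the compounds shown give only this one context for the change. Also open, as far as these compounds go, is whether the hydroxyl itself is what counts at this place, which a 2-methoxyphenyl or 2-aminophenyl group there would begin to test.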